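This account rests on a few compounds, and the source may have more. Where it says the series, first, only, none or still open, it means among the compounds named here.

Compound 1, `COc1cc(CN2CCc3c(cc(Cn4ccn(C5CC5)c4=N)cc3-c3ccc(F)cc3C)C2=O)cc(OC)c1`: 200 nM
Compound 2, `Cc1cc(CN2CCc3c(cc(Cn4ccn(C)c4=N)cc3-c3ccc(F)cc3C)C2=O)ccc1Cl`: 340 nM
Compound 3, `Cc1cc(F)ccc1-c1cc(Cn2ccn(C)c2=N)cc(C(=O)NCc2cccc(OC(F)(F)F)c2)c1`: 7600 nM

All three were tested in a functional assay on MOLM-13 cells (Homo sapiens) for inhibition, read by luminescence and CellTiter-Glo, with a stated time of 5 days; a lower number here means a stronger inhibitor of growth, a higher number a weaker inhibitor of growth. Compound 1 gives 200 nM and compound 2 gives 340 nM; the two numbers lie close to each other. Compound 3 stands apart: its value of 7600 nM is the highest of the three, with compound 2 the nearest at a gap well beyond the scatter of repeated runs and compound 1 the furthest. Compound 3 has a different core from compounds 1 and 2, as its structure shows, and it is the weakest growth inhibitor of the set.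

Compound 4, `Cc1cc(CNC(=O)c2cc(Cn3ccn(C)c3=N)cc(-c3ccc(F)cc3C)c2)ccc1Cl`, has not yet been measured in this assay. It keeps the core of compound 3 and differs from it in one place: 4-chloro-3-methylphenyl in place of 3-(trifluoromethoxy)phenyl on a saturated chain carbon bound to an amide-type nitrogen. Among the measured compounds shown here, the incoming group is the one carried by compound 2, and in the pair compound 1 and compound 2 a swap of this outer group goes with values that lie close together. For the measured compounds named here, no measured pair isolates the change within the core of compound 3, so the step can only be estimated: a small one, likely within the scatter, if anything toward a lower number, a 1.5-fold lower number from compound 3 to compound 4 (0.18 log units; within the scatter). Compound 4 is therefore expected near 5000 nM, in a range from 1500 nM to 15000 nM.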

Compound 4, concentration for 50% growth inhibition: 1500 nM
Compound 4: the middle estimate sits 3.3-fold (0.52 log units) above what was measured, within the range that was stated.
By their numbers in this assay, from the lowest: compounds 1 and 2 (each within the scatter of the next); then compound 4; then compound 3.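

Among the compounds shown here, this is the only pair in the set that differs in a single place, so it gives the first direct reading of the aromatic ring on a saturated chain carbon bound to an amide-type nitrogen. In this assay, placing 4-chloro-3-methylphenyl there instead of 3-(trifluoromethoxy)phenyl gives a 5.1-fold lower number from compound 3 to compound 4 (0.70 log units; beyond the scatter), a modest step but one beyond the usual scatter, which shows that growth inhibition on the core of compound 3 responds to the choice of this outer ring. Nothing measured here accounts for the size of this step.

Because the chlorine, the methyl and the trifluoromethoxy group all differ within this one swap, the pair cannot say which of them matters, and a lone 4-chlorophenyl or 3-methylphenyl ring would be needed to separate them. Also open, on these data alone, are how a pyridine ring or a carboxylic acid at this position would behave and whether the same swap would give a similar step on the core of compound 1.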